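Removing the benzyl from the ring sulfonamide nitrogen

The source may hold more compounds than are shown below. What is called first, only, known or untested is meant among the compounds shown, and "the series" means these compounds.

The three measured compounds were all tested in a functional assay on HEL cells (Homo sapiens); a lower number here means that less compound is tolerated, a higher number that more compound is tolerated.
Compound 1 `O=C1NS(=O)(=O)N(COCc2ccccc2)c2ccccc21`: > 50 ug/mL, a limit of the assay.
Compound 2 `O=C1c2ccccc2N(Cc2ccccc2)S(=O)(=O)N1COCc1ccccc1`: > 40 ug/mL, a limit of the assay.
Compound 3 `O=C1NS(=O)(=O)N(COCCO)c2ccccc21`: 112 ug/mL.

Compound 2 stands at the limit of > 40 ug/mL in this assay, at which 1 of the 3 values shown sits. Compound 1 stands at the limit of > 50 ug/mL in this assay, at which 1 of the 3 values shown sits. Among the measured compounds shown here, only compound 3 gives a number in this assay, and the one single-point step, a step that the limit leaves unreadable from compound 1 to compound 3, stays unreadable. Compound 4 `O=C1c2ccccc2NS(=O)(=O)N1COCc1ccccc1` differs from compound 2 by hydrogen in place of benzyl on a sulfonamide nitrogen in a ring. For the measured compounds named here, no measured step follows this particular change, and the one step that is measured gives no readable size; the data show only that none of the three compounds reaches a cytotoxic concentration below the limits in this assay. Compound 4 is therefore expected to stay tolerated as well, with an estimate of 80 ug/mL and a range from 40 ug/mL to 200 ug/mL. This estimate means a step that the limit leaves unreadable from compound 2 to compound 4 that is expected to stay within the scatter, most likely reported again only as a limit.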

Compound 4, half-maximal cytotoxic concentration: 148 ug/mL
Estimate against measurement, compound 4: 1.9-fold (0.27 log units) below; the measured number falls inside the stated range.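

Among the compounds shown here, the step from compound 2 to compound 4 cannot be read, and no new step follows from this result: compound 2 stands only at a limit, > 40 ug/mL. The compounds shown leave open whether removing the benzyl from the sulfonamide nitrogen in a ring changes the tolerated concentration in this assay at all.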